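A few compounds are considered here, and "the series" means these few. Any claim that something is new, unique, unknown or untested is made for them only; others in the source may bear on it.

Measured so far:
- compound 1, `O=C(CCl)Nc1cccc(Cn2nc(-c3ccc(Oc4ccccc4)cc3)cc2CO)c1`: 400 nM
- compound 2, `C=CC(=O)Nc1cccc(Cn2nc(-c3ccc(Oc4ccccc4)cc3)cc2C(=O)OCC)c1`: 8600 nM
- compound 3, `C/C=C/C(=O)Nc1ccc(Cn2nc(-c3ccc(Oc4ccccc4)cc3)cc2C(=O)OCC)cc1`: > 60000 nM

In a functional assay on Maver1 cells (Homo sapiens) for inhibition, read by luminescence and CellTiter-Glo, with a stated time of 72 h (on this read-out lower numbers stand for stronger inhibition and higher numbers for weaker inhibition), compound 2 gives 8600 nM, the highest of the two numbers on record; compound 1 gives 400 nM. For compound 3 the value > 60000 nM is a limit of the assay, not a number, and it sits at the limit of > 60000 nM in this assay, at which 1 of the 3 values shown sits.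

Compound 4, `C=CC(=O)Nc1cccc(Cn2nc(-c3ccc(Oc4ccccc4)cc3)cc2CO)c1`, is not yet measured. Its change from compound 2 is hydroxymethyl in place of ethoxycarbonyl on an aromatic carbon.

Within the data shown here, the one measured step, an at least 6.9-fold higher number from compound 2 to compound 3 (0.84 log units; beyond the scatter), alters the amide and its position on the phenyl ring and leaves the ester untouched, so it does not bear on this change. Among the measured compounds shown here, compound 1 carries the hydroxymethyl group but also a different amide, and no single-point step connects it to compound 2; their two values only show that the hydroxymethyl compound sits lower. On that basis a lower number is expected for compound 4, though its size is uncertain: the estimated step is a 5.7-fold lower number from compound 2 to compound 4 (0.76 log units; beyond the scatter). Compound 4 is expected at 1500 nM, between 300 nM and 8000 nM.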

Compound 4, half-maximal inhibitory concentration: 6700 nM
The estimate for compound 4 lay 4.5-fold (0.65 log units) below the measured number, within the range that was stated.
By their numbers in this assay, from the lowest: compound 1; then compounds 4 and 2 (each within the scatter of the next). At a limit, above all of these: compound 3.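

In this assay, with the vinyl amide held fixed, hydroxymethyl in place of ethoxycarbonyl on this aromatic carbon gives a 1.3-fold lower number from compound 2 to compound 4 (0.11 log units; within the scatter), so on this amide the change at this position does not separate the two compounds. With hydroxymethyl held fixed, vinyl in place of chloromethyl on the carbonyl carbon gives a 17-fold higher number from compound 1 to compound 4 (1.22 log units; beyond the scatter), so the low number of compound 1 cannot be credited to hydroxymethyl alone and goes with the chloromethyl amide in this pair. Nothing on record gives a measured property that bears on either step.

The compounds shown leave open whether a carboxylic acid or an aminomethyl group on this aromatic carbon would shift the number beyond the scatter. They also leave open whether the chloromethyl amide keeps its low number with ethoxycarbonyl in place of hydroxymethyl.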